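From Racemate to a Single Enantiomer

A few compounds are considered here, and "the series" means these few. Any claim that something is new, unique, unknown or untested is made for them only; others in the source may bear on it.

Compound 1 `Fc1ccc(-c2cn(C3CN4CCC3CC4)nn2)cc1`: 449 nM
Compound 2 `Fc1cccc(-c2cn(C3CN4CCC3CC4)nn2)c1`: 748 nM

Of the compounds shown here, two have been measured in an assay on HEK293 cells for displacement of a labelled ligand from Neuronal acetylcholine receptor; alpha4/beta2 (Homo sapiens), read by scintillation counting, with a stated time of 120 min; on this read-out lower numbers stand for stronger inhibition and higher numbers for weaker inhibition. Compound 1 gives 449 nM, the lowest of the two numbers. Compound 2 gives 748 nM, and the gap between compound 1 and compound 2 lies within the scatter of this assay, so the two cannot be told apart on these numbers.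

Compound 3 `Fc1ccc(-c2cn([C@@H]3CN4CCC3CC4)nn2)cc1` has not yet been measured. It differs from compound 1 in this way: the two compounds have the same atoms and bonds; at least one stereo element is drawn with a configuration in one of them and without one in the other: 1 of 3 stereo elements differ; a stereocentre at a saturated ring carbon is drawn without a configuration in compound 1 and S in compound 3. Compound 1 therefore stands for a mixture of both configurations at that ring carbon, while compound 3 is one of them alone. Within the data shown here, no measured pair shows what such a change does here. If the S form is the one that binds more tightly, compound 3 is expected to give a lower number than compound 1; if it is the weaker one, a much higher number. On balance, compound 3 is estimated at 350 nM, with a range from 120 nM to 1500 nM. The step this estimate implies, a 1.3-fold lower number from compound 1 to compound 3 (0.11 log units; within the scatter), is expected to be modest and toward lower numbers.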

Compound 3, inhibition constant: 515 nM
Compound 3: middle estimate off by 1.5-fold (0.17 log units), on the low side; the range from low to high includes it.
By their numbers in this assay, from the lowest: compounds 1, 3 and 2 (each within the scatter of the next).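

In this assay, fixing the saturated ring carbon as S gives a 1.1-fold higher number from compound 1 to compound 3 (0.06 log units; within the scatter), so the single form cannot be told apart from compound 1, which is drawn without a configuration at that carbon. Among these compounds, this is the first look at the stereocentre, since the earlier compounds offered no comparison of a defined configuration with an undefined one, and it gives no sign that drawing the S form alone changes the reading. The comparison rests on a single structural distinction: the fact that one of compounds 1 and 3 is drawn with a defined configuration and the other without, at the place where they differ

Going by these compounds, how the R form at the same ring carbon would read remains open, and with it how far the two forms differ from each other. Also open, on these data alone, is how the S form would respond if a methoxy group or an amine took the place of the fluorine.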